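A few compounds are considered here, and "the series" means these few. Any claim that something is new, unique, unknown or untested is made for them only; others in the source may bear on it.

In an assay on HEK-293T cells for antagonist activity at vitamin D3 receptor (Homo sapiens), read by a luciferase reporter, with a stated time of 24 h (on this read-out lower numbers stand for stronger inhibition and higher numbers for weaker inhibition), compound 1 `CC(C)c1onc(-c2c(Cl)cccc2Cl)c1COc1ccc(-c2nc3ccc(C(=O)O)cc3n2CC2CCCCC2)c(F)c1` gives 840 nM. Compound 2 `CCCC(CCC)n1c(-c2ccc(OCc3c(-c4c(Cl)cccc4Cl)noc3C(C)C)cc2)nc2ccc(C(=O)O)cc21` returns only a limit of the assay in this assay, > 10000 nM, and so sits at the limit of > 10000 nM in this assay, at which 1 of the 2 values shown sits, without a number of its own. Compound 3 `CC(C)c1onc(-c2c(Cl)cccc2Cl)c1COc1ccc(-c2nc3ccc(C(=O)O)cc3n2CC2CCCCC2)cc1` follows by one change: cyclohexylmethyl in place of 1-propylbutyl on an aromatic nitrogen. Among the measured compounds shown here, no measured step joins the two, so the expectation rests on compound 1, which carries the same cyclohexylmethyl group and gives 840 nM. Compound 3 is thus estimated at 1500 nM, ranging from 500 nM to 5000 nM. The expected step from compound 2 to compound 3 is an at least 6.6-fold lower number from compound 2 to compound 3 (0.82 log units; beyond the scatter), a gain, set against a limit only.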

Compound 3, half-maximal inhibitory concentration: 346 nM
For compound 3 the middle estimate is 4.3-fold (0.64 log units) above the measured one; measured number below the stated range.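

In this assay cyclohexylmethyl in place of 1-propylbutyl on an aromatic nitrogen brings an at least 28-fold lower number from compound 2 to compound 3 (1.46 log units; beyond the scatter) with the same count of heavy atoms, so at this place a ring and an open chain of equal size part clearly. Compound 2 gives only a limit of the assay: the limit of > 10000 nM in this assay, at which 1 of the 3 values shown sits. With cyclohexylmethyl held, hydrogen in place of fluoro on an aromatic carbon brings a 2.4-fold lower number from compound 1 to compound 3 (0.39 log units; beyond the scatter) as a smaller further gain.

The compounds shown leave open how cyclopentylmethyl or a piperidinylmethyl group, which carries an amine, would read at this nitrogen.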